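The compounds below may be only part of what the source reports. "The series", "measured", "known", "first", "only" and "open" are said of these compounds alone.

Compound 3 `COc1cc(C(=O)N2CCN(C(=O)c3cc(OC)c(OC)c(OC)c3)C(COC(=O)NCCC(C)C)C2)cc(OC)c1OC` stands second highest of the three numbers measured in a functional assay (Oryctolagus cuniculus) for inhibition of platelet-activating factor receptor (Cavia porcellus) (a higher number here means a weaker inhibitor, a lower number a stronger inhibitor), where compound 3 gives 140 nM. Compound 1 `CCCC(C)NC(=O)OCC1CN(C(=O)c2cc(OC)c(OC)c(OC)c2)CCN1C(=O)c1cc(OC)c(OC)c(OC)c1` gives 100 nM and compound 2 `CCC(C)(C)NC(=O)OCC1CN(C(=O)c2cc(OC)c(OC)c(OC)c2)CCN1C(=O)c1cc(OC)c(OC)c(OC)c1` gives 320 nM. Compound 4 `CCCCN(CCCC)C(=O)OCC1CN(C(=O)c2cc(OC)c(OC)c(OC)c2)CCN1C(=O)c1cc(OC)c(OC)c(OC)c1` differs from compound 3 by dibutylamino in place of isopentylamino on a carbonyl carbon. The measured steps all change the group on the amide-type nitrogen: a 1.4-fold higher number from compound 1 to compound 3 (0.15 log units; within the scatter) and a 2.3-fold lower number from compound 2 to compound 3 (0.36 log units; beyond the scatter), the latter modest. Within the data shown here, no measured step removes the hydrogen-bond donor or brings in a second chain, so the bearing of these steps is indirect. A modest weakening is therefore expected, with wide uncertainty: the step from compound 3 to compound 4 is estimated as a 2.1-fold higher number from compound 3 to compound 4 (0.33 log units; beyond the scatter). Compound 4 is expected to give about 300 nM in this assay, within a range of 80 nM to 1200 nM.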

Compound 4, half-maximal inhibitory concentration: 1250 nM
Compound 4: the middle estimate sits 4.2-fold (0.62 log units) below what was measured; the measured number lies above the stated range.
By their numbers in this assay, from the lowest: compounds 1 and 3 (each within the scatter of the next); then compound 2; then compound 4.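

Compound 4 gives the highest number of the four, with every step to it beyond the scatter: an 8.9-fold higher number from compound 3 to compound 4 (0.95 log units; beyond the scatter), a 3.9-fold higher number from compound 2 to compound 4 (0.59 log units; beyond the scatter) and a 13-fold higher number from compound 1 to compound 4 (1.10 log units; beyond the scatter). So this position accepts reshaping among the amines that keep the hydrogen-bond donor, yet inhibition weakens clearly with dibutylamino, which has no such donor and more heavy atoms. No measurement at hand explains this weakening. The compounds shown cannot tell whether the missing donor or the larger group matters more. Dimethylamino, which also lacks the donor but carries far fewer carbons, would help separate the two.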